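The source may report more compounds than this note shows. Statements on the series, on what has been measured and on what is new or still open speak of the compounds shown alone.

Within the data shown here, compound 1 `O=C(O)CCc1ccc(NCc2ccccc2)cc1` gives 89% in a functional assay on 1321-N1 cells for agonist activity at Free fatty acid receptor 1 (Homo sapiens), read by calcium flux (on this read-out higher numbers stand for larger maximal responses and lower numbers for smaller maximal responses), the lowest of the three numbers measured so far. Compound 2 `O=C(O)CCc1ccc(NCc2ccc(Oc3ccccc3)cc2)cc1` gives 100% in this assay, and compound 3 `O=C(O)CCc1ccc(NCc2ccccc2-c2ccccc2)cc1` gives 97%. Compound 4 `Cc1ccc(-c2cccc(CNc3ccc(CCC(=O)O)cc3)c2)cc1` differs from compound 1 by 4-methylphenyl in place of hydrogen on an aromatic carbon, sitting meta to a large group. Among the measured compounds shown here, two measured steps bear on this change: a number 11 percentage points higher from compound 1 to compound 2 (beyond the scatter), and a number 8 percentage points higher from compound 1 to compound 3 (within the scatter). Both replace a hydrogen on the core of compound 1 with a ring-bearing group, and both move the number upward, one beyond and one within the scatter. A similar small rise in this assay is therefore expected for compound 4, roughly a number 8 percentage points higher from compound 1 to compound 4 (within the scatter). Compound 4 is estimated at 97%, with a range from 88% to 104%.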

Compound 4, largest response reached (reported as efficacy), in percent of the reference or control that the assay uses: 92%
Estimate against measurement, compound 4: 5 percentage points above, within the range that was stated.
By their numbers in this assay, from the lowest: compounds 1, 4, 3 and 2 (each within the scatter of the next, the first and the last beyond it).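

In this assay, placing 4-methylphenyl on an aromatic carbon, meta to a large group, gives a number 3 percentage points higher from compound 1 to compound 4 (within the scatter), so at this position a whole added ring produces no change that can be told apart from the scatter. Nothing available explains this result.

The compounds shown leave open what the methyl of the 4-methylphenyl group contributes on its own. They also leave open whether an amine or a carboxylic acid in place of that methyl would give a step beyond the scatter.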